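Cyclopropane bis-amide series: aryl substituent and growth inhibition

The compounds below may be only part of what the source reports. "The series", "measured", "known", "first", "only" and "open" are said of these compounds alone.

Measured compounds:
compound 1 `CN(C)C(=O)c1cc2cnc(Nc3ccc(NC(=O)C4(C(=O)Nc5ccc(F)cc5)CC4)cc3)nc2n1C1CCCC1` 74.7%
compound 2 `CN(C)C(=O)c1cc2cnc(Nc3ccc(NC(=O)C4(C(=O)Nc5ccc(Cl)cc5)CC4)cc3)nc2n1C1CCCC1` 22.8%
compound 3 `CN(C)C(=O)c1cc2cnc(Nc3ccc(NC(=O)C4(C(=O)Nc5cccc(F)c5)CC4)cc3)nc2n1C1CCCC1` -3.2%

All three share one core and differ only in the aryl group on the amide-type nitrogen. In a functional assay on T47D cells (Homo sapiens) for inhibition, read by CCK-8 assay, with a stated time of 72 h, tested at 1 uM (on this read-out lower numbers stand for less inhibition of growth and higher numbers for more inhibition of growth at the one concentration tested), compound 1 gives 74.7%, the highest of the three. Compound 2 stands second on this read-out: the step of a number 51.9 percentage points lower from compound 1 to compound 2 (beyond the scatter) is large, and the step of a number 26 percentage points lower from compound 2 to compound 3 (beyond the scatter) is modest, so compound 2 sits between the other two, separated from each beyond the scatter. The step of a number 77.9 percentage points lower from compound 1 to compound 3 (beyond the scatter) shows how far the series spans.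

Compound 4 `CN(C)C(=O)c1cc2cnc(Nc3ccc(NC(=O)C4(C(=O)Nc5ccc(O)cc5)CC4)cc3)nc2n1C1CCCC1` has not yet been measured. It differs from compound 2 by hydroxy in place of chloro on an aromatic carbon. Within the data shown here, the only measured step that changes the group at this same place is a number 51.9 percentage points lower from compound 1 to compound 2 (beyond the scatter), where chloro in place of fluoro lowered the read-out strongly. Nothing measured yet holds a hydroxy group, so the direction of the step to compound 4 is not well anchored; a change of some size beyond the scatter is plausible in either direction. Compound 4 is therefore expected to give about 40%, within 0% to 80%, which means an estimated step of a number 17.2 percentage points higher from compound 2 to compound 4 (beyond the scatter).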

Compound 4, percent growth inhibition at one concentration: 91.5%
Compound 4: middle estimate off by 51.5 percentage points, on the low side; measured number above the stated range.
By their numbers in this assay, from the lowest: compound 3; then compound 2; then compound 1; then compound 4.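

In this assay the place para to a large group proves able to carry the read-out upward as well as downward: hydroxy in place of chloro gives a number 68.7 percentage points higher from compound 2 to compound 4 (beyond the scatter) and hydroxy in place of fluoro gives a number 16.8 percentage points higher from compound 1 to compound 4 (beyond the scatter), so fluoro no longer marks the top of the series, and the swap of a single heavy atom at this place, with hydroxy bringing a hydrogen-bond donor and acceptor that both halogens lack, spans the whole range seen among the compounds with a group at this place. The widest gap in the series is now a number 94.7 percentage points higher from compound 3 to compound 4 (beyond the scatter), a comparison in which the group and its place on the ring both differ, so it cannot assign the change to either alone. Nothing at hand accounts for the size or direction of these steps.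

From the compounds shown here alone, whether an amino or methoxy group at this place would follow hydroxy, and whether 3-hydroxyphenyl would escape the low read-out of the 3-fluorophenyl compound, stays open. With a single tested concentration, the compounds also leave open how the order would hold across a range of concentrations.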